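Fluoro in Place of Nitro on the Amide Aryl Ring

This account rests on a few compounds, and the source may have more. Where it says the series, first, only, none or still open, it means among the compounds named here.

Compound 1 `O=C(Nc1nc(-c2ccccc2)nc2c1nnn2Cc1ccccc1)c1cccc([N+](=O)[O-])c1` is the weaker of the two measured compounds in an assay (strain Wistar) for displacement of a labelled ligand from adenosine receptor A1 (Rattus norvegicus), read by scintillation counting; a higher number here means a weaker inhibitor, a lower number a stronger inhibitor: compound 1 gives 77 nM, whereas compound 2 `O=C(Nc1nc(-c2ccccc2)nc2c1nnn2Cc1ccccc1)c1ccoc1` gives 10 nM. Going by the values given here, the only measured step, a 7.7-fold lower number from compound 1 to compound 2 (0.89 log units; beyond the scatter), swaps the whole aryl group on the carbonyl carbon. Compound 3 `O=C(Nc1nc(-c2ccccc2)nc2c1nnn2Cc1ccccc1)c1cccc(F)c1` differs from compound 1 in a smaller way: fluoro in place of nitro on an aromatic carbon, on an aromatic carbon of a six-membered aromatic ring of carbon only, meta to a large group. Among the compounds with values here, no measured step covers a fluoro in place of a nitro, so the step from compound 1 to compound 2 bears on it only as a hint that altering this part of the molecule moved the number, and that it fell when the nitro-bearing ring was replaced. For compound 3 a step in the same direction but of smaller size is expected, a 1.9-fold lower number from compound 1 to compound 3 (0.28 log units; within the scatter). For compound 3 the estimate is 40 nM, with a range from 10 nM to 160 nM.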

Compound 3, inhibition constant: 22 nM
For compound 3 the middle estimate is 1.8-fold (0.26 log units) above the measured one; the measured number falls inside the stated range.
By their numbers in this assay, from the lowest: compound 2; then compound 3; then compound 1.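

Keeping the phenyl ring and changing only its substituent gives a 3.5-fold lower number from compound 1 to compound 3 (0.54 log units; beyond the scatter) in this assay, so the nitro group is not required for binding at this place, and a single fluorine atom serves better. Much of the gain seen with furan-3-yl is therefore reached without giving up the phenyl ring, although furan-3-yl still stands ahead, with a 2.2-fold higher number from compound 2 to compound 3 (0.34 log units; beyond the scatter) as the remaining gap. Nothing measured here explains why either change lowers the number.

Going by these compounds, with only nitro and fluoro compared on this ring, the trend across other substituents is unknown. An unsubstituted phenyl ring would show whether fluoro itself helps or nitro simply hinders, while a methoxy group, an amine or a carboxylic acid at the same place remains an open question.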